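Removing the pyrimidine fluoro from compound 3

The source may report more compounds than this note shows. Statements on the series, on what has been measured and on what is new or still open speak of the compounds shown alone.

Compound 1 `O=C(Nc1cc(F)c(F)c(F)c1)N1Cc2c(-c3ccc(F)cc3F)cnn2CC1C1CC1`: 32100 nM
Compound 2 `CC1(C)CC(=O)N(c2cnn3c2CN(C(=O)Nc2cc(F)c(F)c(F)c2)C(C2CC2)C3)C1`: 115000 nM
Compound 3 `O=C1CC(c2ncc(F)cn2)CN1c1cnn2c1CN(C(=O)Nc1cc(F)c(F)c(F)c1)C(C1CC1)C2`: 115000 nM

In a toxicity assay on HepG2 2.2.15 cells (Homo sapiens) for cytotoxicity, read by CellTiter-Glo (a higher number here means that more compound is tolerated, a lower number that less compound is tolerated), compound 3 gives 115000 nM and shows no change from compound 2 at the digits given. Compound 1 gives 32100 nM. The gap that separates it from compound 2 and from compound 3 lies beyond the scatter.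

The next compound is compound 4 `O=C1CC(c2ncccn2)CN1c1cnn2c1CN(C(=O)Nc1cc(F)c(F)c(F)c1)C(C1CC1)C2`, with hydrogen in place of fluoro on an aromatic carbon of a six-membered aromatic ring with 2 nitrogen, para to a large group. The same difference reads 5-fluoropyrimidin-2-yl to pyrimidin-2-yl: hydrogen in place of fluoro on an aromatic carbon.

Among the measured compounds shown here, only one measured step is available: a 3.6-fold higher number from compound 1 to compound 2 (0.55 log units; beyond the scatter), with 4,4-dimethyl-2-oxopyrrolidin-1-yl in place of 2,4-difluorophenyl. It bears only loosely on this change, as it exchanges a different group at a different place. For the measured compounds named here, no measured step tests this fluoro, so no shift in either direction beyond the scatter is expected in this assay.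

The estimated change is a 1.0-fold lower number from compound 3 to compound 4 (0.02 log units; within the scatter) and is expected to stay within the scatter. For compound 4 the estimated value is 110000 nM, with an expected range of 60000 nM to 190000 nM.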

Compound 4, half-maximal cytotoxic concentration: > 200000 nM
Compound 4 ended at the assay's limit (the forecaster's own chance of this, stated with the estimate: 25%); middle value at least 1.8-fold (0.25 log units) away from the limit.
By their numbers in this assay, from the lowest: compound 1; then compounds 2 and 3 (each within the scatter of the next). At a limit, above all of these: compound 4.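

In this assay compound 4 gives > 200000 nM, a limit of the assay and not a number: the limit of > 200000 nM in this assay, at which 1 of the 4 values shown sits. The earlier compounds shown here held no comparison at this position, and hydrogen in place of fluoro on the pyrimidine carbon, para to a large group, gives no lower number: the step reads an at least 1.7-fold higher number from compound 3 to compound 4 (0.24 log units; that floor lies within the scatter). Among the compounds shown here, with the 2-oxo-4-(pyrimidin-2-yl)pyrrolidin-1-yl group, the reading is an at least 1.7-fold higher number from compound 2 to compound 4 (0.24 log units; that floor lies within the scatter) and an at least 6.2-fold higher number from compound 1 to compound 4 (0.79 log units; beyond the scatter), and only this last step, which replaces 2,4-difluorophenyl, is beyond the scatter.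

How far compound 4 actually stands from compound 3 remains undefined. Also open, going by these compounds, is whether chloro, methoxy or an amine on this pyrimidine carbon would lower the number in this assay.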